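The source may hold more compounds than are shown below. What is called first, only, known or untested is meant among the compounds shown, and "the series" means these compounds.

Measured so far:
compound 1 `CNC(=O)COc1cc(=O)oc2cc(OCc3cccc(Cl)c3)ccc12` — 33.9 nM
compound 2 `O=c1cc(CO)c2ccc(OCc3cccc(Br)c3)cc2o1` — 14.1 nM

In an assay on isolated protein (strain Sprague-Dawley) for inhibition of Amine oxidase [flavin-containing] B (Rattus norvegicus), read by spectrophotometry, with a stated time of 5 min (on this read-out higher numbers stand for weaker inhibition and lower numbers for stronger inhibition), compound 1 gives the higher of the two numbers; the gap to compound 2 lies beyond the scatter. Compound 3 `CCOC(=O)c1cc(=O)oc2cc(OCc3cccc(Cl)c3)ccc12` has not been measured. It differs from compound 1 in one place: ethoxycarbonyl in place of (methylcarbamoyl)methoxy on an aromatic carbon. Going by the values given here, no step between measured compounds bears on this exchange, so the expectation rests on compound 1 alone and on compound 2 as the other point. A modest step toward stronger inhibition, a 1.7-fold lower number from compound 1 to compound 3 (0.23 log units; within the scatter), is expected, not far beyond the scatter. For compound 3 the estimate is 20 nM, within 5 nM to 80 nM.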

Compound 3, half-maximal inhibitory concentration: 417 nM
Beside the measured number, compound 3's estimate is 21-fold (1.32 log units) below it; measured number above the stated range.
By their numbers in this assay, from the lowest: compound 2; then compound 1; then compound 3.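

In this assay this position on the shared core responds strongly to the exchange: ethoxycarbonyl in place of (methylcarbamoyl)methoxy brings a 12-fold higher number from compound 1 to compound 3 (1.09 log units; beyond the scatter) and so the two groups are not interchangeable here. The exchange removes the one hydrogen-bond donor of the leaving group and keeps the count of hydrogen-bond acceptors unchanged. No measurement at hand accounts for this step. Still open, going by these compounds, is which part of (methylcarbamoyl)methoxy carries the difference. On these data alone, how a carboxylic acid or an amine would read at this position also remains unknown.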